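Swapping Methyl for Tert-Butyl on an Aromatic Carbon

The source may report more compounds than this note shows. Statements on the series, on what has been measured and on what is new or still open speak of the compounds shown alone.

Compound 1 `CCc1ccc(SCc2ccc(/C=C/C(=O)Nc3ccccc3N)cc2)cc1` gives 2.68%
Compound 2 `Nc1ccccc1NC(=O)/C=C/c1ccc(CSc2ccc(C(F)(F)F)cn2)cc1` gives 14.9%
Compound 3 `Cc1ccc(SCc2ccc(/C=C/C(=O)Nc3ccccc3N)cc2)cc1` gives 4.93%

In a functional assay on HCT-116 cells (Homo sapiens) for inhibition, read by CCK-8 assay, with a stated time of 72 h, tested at 8 uM (a lower number here means less inhibition of growth, a higher number more inhibition of growth at the concentration tested), compound 3 lies within the scatter of both compound 1 and compound 2, whose own gap is the only one beyond it. Going by these compounds, compound 4 `CC(C)(C)c1ccc(SCc2ccc(/C=C/C(=O)Nc3ccccc3N)cc2)cc1` carries tert-butyl in place of methyl on an aromatic carbon, para to a large group tert-butyl in place of methyl on an aromatic carbon and remains untested. The closest measured change between alkyl groups is a number 2.3 percentage points higher from compound 1 to compound 3 (within the scatter) and it offers little reason to expect a shift. The larger a number 12.2 percentage points higher from compound 1 to compound 2 (beyond the scatter) brings in 5-(trifluoromethyl)pyridin-2-yl, which is no alkyl group, so it bears only weakly here. The expected a number 0.1 percentage points higher from compound 3 to compound 4 (within the scatter) therefore stays within the scatter in this assay with no direction favoured. For compound 4 the estimated value is 5% (expected range 0% to 14%).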

Compound 4, percent growth inhibition at one concentration: 39%
The estimate for compound 4 lay 34 percentage points below the measured number; measured number outside the range, above it.
By their numbers in this assay, from the lowest: compounds 1, 3 and 2 (each within the scatter of the next, the first and the last beyond it); then compound 4.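

In this assay, the alkyl group on this aromatic carbon, para to a large group, turned out to matter greatly: methyl and ethyl had stayed within the scatter of each other, yet tert-butyl gives a number 34.1 percentage points higher from compound 3 to compound 4 (beyond the scatter) and a number 36.3 percentage points higher from compound 1 to compound 4 (beyond the scatter). The whole 4-(tert-butyl)phenyl group on the sulfur also surpasses 5-(trifluoromethyl)pyridin-2-yl, with a number 24.1 percentage points higher from compound 2 to compound 4 (beyond the scatter). No measurement at hand accounts for this jump. Going by these compounds, whether isopropyl or cyclopropyl at this position would give a similar gain remains open, as does the outcome with a polar substituent such as an amine or a carboxylic acid.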